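Cyano in place of methoxy in a flat series

A few compounds are considered here, and "the series" means these few. Any claim that something is new, unique, unknown or untested is made for them only; others in the source may bear on it.

Measured in a functional assay (Nicotiana tabacum) (on this read-out higher numbers stand for weaker inhibition and lower numbers for stronger inhibition), so far:
- Compound 1 `CSc1nc(Nc2ccc(Cl)cc2)c2cccnc2n1` gives 8510 nM
- Compound 2 `CCc1ccc(Nc2nc(SC)nc3ncccc23)cc1` gives 7150 nM
- Compound 3 `COc1ccc(Nc2nc(SC)nc3ncccc23)cc1` gives 9420 nM

Compound 3 at 9420 nM cannot be told apart from the other two compounds, as all three values lie within the usual scatter of repeated measurements. The next compound is compound 4 `CSc1nc(Nc2ccc(C#N)cc2)c2cccnc2n1` which keeps the shared core and changes one group. The swap is cyano in place of methoxy on an aromatic carbon. The measured steps at that carbon are a 1.2-fold lower number from compound 1 to compound 2 (0.08 log units; within the scatter) and a 1.1-fold higher number from compound 1 to compound 3 (0.04 log units; within the scatter) and a 1.3-fold higher number from compound 2 to compound 3 (0.12 log units; within the scatter) and none of them leaves the scatter. Chloro, ethyl and methoxy therefore read alike here, but no measured compound carries cyano, so the range must stay wide. No step beyond the scatter is expected in this assay in either direction. The expected step is a 1.2-fold lower number from compound 3 to compound 4 (0.07 log units; within the scatter) and so stays small. Compound 4 is estimated at 8000 nM with 3500 nM to 18000 nM as the expected range.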

Compound 4, half-maximal inhibitory concentration: 7560 nM
For compound 4 the middle estimate is 1.1-fold (0.02 log units) above the measured one; measured number inside the range.
By their numbers in this assay, from the lowest: compounds 2, 4, 1 and 3 (each within the scatter of the next).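

In this assay cyano joins chloro, ethyl and methoxy at this aromatic carbon without standing apart from any of them: the steps are a 1.2-fold lower number from compound 3 to compound 4 (0.10 log units; within the scatter) and a 1.1-fold higher number from compound 2 to compound 4 (0.02 log units; within the scatter) and a 1.1-fold lower number from compound 1 to compound 4 (0.05 log units; within the scatter) and all three lie within the scatter. Among the compounds shown here, the flat reading therefore now covers four different groups at this position, including one with a triple bond, which the earlier compounds could not show. Nothing at hand explains why these groups read alike.

On these data alone, what remains open is whether any group at this carbon, such as an amine, a carboxylic acid or a longer chain, would give a step beyond the scatter. All four compounds also keep the shared core, so they leave open whether a change elsewhere in the molecule would move the number.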